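Removing One Methyl From an Inactive Pair

The source may hold more compounds than are shown below. What is called first, only, known or untested is meant among the compounds shown, and "the series" means these compounds.

compound 1 `O=C(CSC(=S)N[C@H]1CCOC1=O)Nc1ccccc1F`, a limit only: > 128000 nM
compound 2 `Cc1cccc(NC(=O)CSC(=S)N[C@H]2CCOC2=O)c1C`, a limit only: > 128000 nM

In a functional assay on EC9706 cells (Homo sapiens) for cytotoxicity, read by MTT assay, with a stated time of 72 h (a lower number here means a stronger inhibitor, a higher number a weaker inhibitor), compound 1 reaches only the limit of the assay, > 128000 nM. Compound 2 likewise gives only a limit, > 128000 nM. Compound 2 therefore stands at the limit of > 128000 nM in this assay, at which 2 of the 2 values shown sit, with no number of its own. Compound 3 `Cc1cccc(NC(=O)CSC(=S)N[C@H]2CCOC2=O)c1` differs from compound 2 by hydrogen in place of methyl on an aromatic carbon. Among the measured compounds shown here, with no measured step to draw on, the expected step from compound 2 to compound 3 is a step that the limit leaves unreadable from compound 2 to compound 3, nothing beyond the scatter. Compound 3 is expected to give 200000 nM, between 60000 nM and 700000 nM, most likely again only a limit.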

Compound 3, half-maximal inhibitory concentration: > 128000 nM
Compound 3 was reported as a limit (the forecaster's own chance of this, stated with the estimate: 85%); the middle value does not contradict the limit.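

Compound 3 gives only a limit, as do compound 1 and compound 2, so no step among these compounds can be read: the limit of > 128000 nM in this assay, at which 3 of the 3 values shown sit.

The compounds shown leave open whether any change to the aromatic ring can give a true number in this assay.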